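The source may hold more compounds than are shown below. What is called first, only, known or untested is meant among the compounds shown, and "the series" means these compounds.

Measured so far in an ADME assay on HEK293 cells (Homo sapiens) for cytotoxicity, read by reporter gene assay and resazurin assay, with a stated time of 48 h; a higher number here means that more compound is tolerated, a lower number that less compound is tolerated:
compound 1 `O=C(Nc1ccc(Sc2nc3ccccc3s2)c(Cl)c1)c1cc(Br)cc(Br)c1`: > 100000 nM
compound 2 `O=C(Nc1ccc(Sc2nc3ccccc3s2)cc1)c1cc(Br)cc(Br)c1`: > 100000 nM
compound 3 `COc1ccccc1C(=O)Nc1ccc(Sc2nc3ccccc3s2)cc1`: > 100000 nM

Compound 1 stands at a limit of the assay, > 100000 nM, and has no actual number. It is not alone in this, as the series shows (the limit of > 100000 nM in this assay, at which 3 of the 3 values shown sit).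

Compound 4 `O=C(Nc1ccc(Sc2nc3ccccc3s2)c(Cl)c1)c1cccc(Br)c1` has not yet been measured. Its difference from compound 1 is hydrogen in place of bromo on an aromatic carbon, so that 3,5-dibromophenyl becomes 3-bromophenyl.

Among the measured compounds shown here, two measured steps bear on this change. The closer one, hydrogen in place of chloro on an aromatic carbon, is a step that the two limits leave unreadable from compound 1 to compound 2. The larger change, 2-methoxyphenyl in place of 3,5-dibromophenyl on a carbonyl carbon, is a step that the two limits leave unreadable from compound 2 to compound 3. Neither size can be read, yet neither change brought a number into this assay. No step beyond the scatter is therefore expected, and no direction can be given.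

The expected change is a number no higher from compound 1 to compound 4 (the limit leaves the size open).

Compound 4 is expected at 100000 nM, with an estimated range of 40000 nM to 150000 nM.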

Compound 4, half-maximal cytotoxic concentration: > 100000 nM
Compound 4: a limit, no number; the forecaster's own chance of this, stated with the estimate: 85%; the middle value lies on the limit itself.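

Compound 4, like compound 1, gives a limit and no number in this assay, so no step between them can be read: the limit of > 100000 nM in this assay, at which 4 of the 4 values shown sit.

The compounds shown leave open at what concentration any of them reaches half-maximal cytotoxicity, and whether any of these changes shifts it.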